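This account rests on a few compounds, and the source may have more. Where it says the series, first, only, none or still open, it means among the compounds named here.

Measured so far in a functional assay on DU-145 cells (Homo sapiens) for inhibition, read by MTT assay, with a stated time of 2 days; on this read-out higher numbers stand for weaker inhibition of growth and lower numbers for stronger inhibition of growth:
compound 1 `O=C(Nn1c(-c2cccc([N+](=O)[O-])c2)nc2c(-c3ccc(Cl)cc3)n[nH]c2c1=O)c1ccccc1` — 17100 nM
compound 2 `COc1cccc(Cc2nc3c(-c4ccc(Cl)cc4)n[nH]c3c(=O)n2NC(=O)c2ccccc2)c1` — 44900 nM

Among the compounds with values here, compound 2 holds the highest of the two numbers in this assay; its only neighbour is compound 1, and the step of a 2.6-fold higher number from compound 1 to compound 2 (0.42 log units; beyond the scatter) is beyond the scatter, so compound 2 is the weaker of the two on this read-out.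

Compound 3 `CCCCCc1nc2c(-c3ccc(Cl)cc3)n[nH]c2c(=O)n1NC(=O)c1ccccc1` is not yet measured. Its change from compound 2 is butyl in place of 3-methoxyphenyl on a saturated chain carbon bound to an aromatic carbon. Within the data shown here, no measured step bears on this exchange: the single step known swaps an aryl group for a benzyl group at the same position, which is a different kind of change, and nothing measured speaks to shortening the substituent to a plain chain. The expectation therefore rests on compound 2 alone, with no reason to expect a step beyond the scatter in either direction; the expected step is a 1.1-fold lower number from compound 2 to compound 3 (0.05 log units; within the scatter). Compound 3 is estimated at 40000 nM, within 14000 nM to 115000 nM.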

Compound 3, concentration for 50% growth inhibition: 22100 nM
Compound 3: the middle estimate sits 1.8-fold (0.26 log units) above what was measured; low and high end bracket the measured number.
By their numbers in this assay, from the lowest: compounds 1 and 3 (each within the scatter of the next); then compound 2.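

In this assay, the exchange of 3-methoxyphenyl for butyl on the saturated chain carbon gives a 2.0-fold lower number from compound 2 to compound 3 (0.31 log units; beyond the scatter) and so shows that this position needs no aromatic ring for growth inhibition at this level. Pentyl directly on the aromatic carbon also stands level with the 3-nitrophenyl group, with a 1.3-fold higher number from compound 1 to compound 3 (0.11 log units; within the scatter) lying within the scatter, so among the groups shown a plain chain serves as well as the directly attached aryl group. No available evidence accounts for either step.

From the compounds shown here alone, whether a longer chain or a branched chain such as isobutyl would hold this level remains open. Also open, going by these compounds, are a pentyl chain ending in an amine or a carboxylic acid, and an unsubstituted benzyl group, which would separate the ring from its methoxy group.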